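The source may report more compounds than this note shows. Statements on the series, on what has been measured and on what is new or still open speak of the compounds shown alone.

Compound 1 `C=CC(=O)NC1CN(S(=O)(=O)c2ccc(NC(=O)OCc3ccccc3)cc2)C1`: > 6 h
Compound 2 `C=CC(=O)NC1CCN(S(=O)(=O)c2ccc(C(=O)N[C@@H]3C[C@H]3c3ccccc3)cc2)CC1`: > 6 h

Both compounds were tested in an ADME assay on a cell-free system (plasma, Mus musculus) for metabolic stability, tested at 1 uM; on this read-out lower numbers stand for a shorter-lived compound and higher numbers for a longer-lived compound. Compound 2 gives > 6 h, which is a limit and not an exact number. Compound 1 also gives only a limit, > 6 h. The two results therefore share a single mark: the limit of > 6 h in this assay, at which 2 of the 2 values shown sit. Neither compound can be placed more exactly.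

Compound 3 `C=CC(=O)NC1CCN(S(=O)(=O)c2ccc(C(=O)NCCC3CCCCC3)cc2)CC1` has not yet been measured. It differs from compound 2 at one place, with 2-cyclohexylethyl in place of 2-phenylcyclopropyl on an amide-type nitrogen. The ring count changes with this swap, and the aromatic ring of compound 2 is gone.

Going by the values given here, no measured pair shows what a change of this kind does in this assay. The expectation therefore rests on the limit of compound 2, > 6 h, and on the matching limit of compound 1. The expected change is no larger than the usual scatter, with no firm direction, and is estimated as a step that the limit leaves unreadable from compound 2 to compound 3. Another limit would be no surprise. For compound 3 the estimated half-life is 7 h, with an expected range from 4 h to 12 h.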

Compound 3, half-life: > 6 h
Compound 3: no number, only a limit (the forecaster's own chance of this, stated with the estimate: 75%); the middle value does not contradict the limit.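

In this assay compound 3 gives > 6 h, which is a limit and not a number. No step from compound 2 to compound 3 can be read, because both results are limits: the limit of > 6 h in this assay, at which 3 of the 3 values shown sit.

The compounds shown leave open how long each one actually lasts, and whether 2-cyclohexylethyl in place of 2-phenylcyclopropyl changes the half-life at all.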